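The source may report more compounds than this note shows. Statements on the series, on what has been measured and on what is new or still open speak of the compounds shown alone.

Working notes on the series. The shared core of compound 1 `COc1cc(Cl)cc(-c2nn(-c3cccc(NC(=O)Nc4ccc(Cl)c(C(F)(F)F)c4)c3)cc2-c2ccncc2)c1`, compound 2 `COc1cc(Cl)cc(-c2nn(-c3cccc(NC(=O)Nc4ccc(Cl)c(Cl)c4)c3)cc2-c2ccncc2)c1` and compound 3 `COc1cc(Cl)cc(-c2nn(-c3cccc(NC(=O)Nc4cccc(C(F)(F)F)c4)c3)cc2-c2ccncc2)c1` is held constant, and the three differ only in the aryl group on the urea. In a functional assay on HT-29 cells (Homo sapiens) for inhibition, read by sulforhodamine B assay, with a stated time of 48 h, tested at 0.1 uM (on this read-out higher numbers stand for a weaker effect at the one concentration tested and lower numbers for a stronger effect), compound 1 gives 94%, compound 2 gives 91% and compound 3 gives 95%. The steps of a number 3 percentage points lower from compound 1 to compound 2 (within the scatter), a number 1 percentage points higher from compound 1 to compound 3 (within the scatter) and a number 4 percentage points higher from compound 2 to compound 3 (within the scatter) are all within the scatter, so the three numbers are indistinguishable, and compound 3 stands among them rather than apart from them.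

Compound 4 `COc1cc(Cl)cc(-c2nn(-c3cccc(NC(=O)c4cccc(C(F)(F)F)c4)c3)cc2-c2ccncc2)c1` differs from compound 3 in one place: 3-(trifluoromethyl)phenyl in place of (3-(trifluoromethyl)phenyl)amino on a carbonyl carbon. Among the compounds with values here, none of the measured steps changes the urea itself; each only swaps substituents on the aryl ring, and each stayed within the scatter. Within the data shown here, there is therefore no measured step that bears directly on this change, and the one indirect lesson is that the numbers in this assay have so far not moved beyond the scatter at all. On that basis compound 4 is expected to stay close to compound 3, with an estimated step of a number 3 percentage points lower from compound 3 to compound 4 (within the scatter). The expected value for compound 4 is 92%, in a range from 78% to 102%.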

Compound 4, a percentage reported as activity, at one concentration (the size of the read-out at that concentration, not a potency): 93%
The estimate for compound 4 lay 1 percentage points below the measured number; the range from low to high includes it.
By their numbers in this assay, from the lowest: compounds 2, 4, 1 and 3 (each within the scatter of the next).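

Within the data shown here, this is the first step that alters the urea itself rather than a substituent on the aryl ring: 3-(trifluoromethyl)phenyl replaces (3-(trifluoromethyl)phenyl)amino on a carbonyl carbon, turning the urea into an amide and removing its nitrogen and hydrogen-bond donor. In this assay this gives a number 2 percentage points lower from compound 3 to compound 4 (within the scatter), and the comparisons giving a number 2 percentage points higher from compound 2 to compound 4 (within the scatter) and a number 1 percentage points lower from compound 1 to compound 4 (within the scatter) are also within the scatter, so the read-out at this one concentration does not distinguish the amide from the three ureas. Nothing available explains this result.

Going by these compounds, it remains open whether a plain amine in place of the carbonyl, or a carboxylic acid on the aryl ring, would move the number beyond the scatter. Also open, on these data alone, is whether the urea and amide would differ at other concentrations.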